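This account rests on a few compounds, and the source may have more. Where it says the series, first, only, none or still open, it means among the compounds named here.

Working notes on the series.

The shared core is held in three measured compounds. Compound 1 `C[C@@H](O)[C@H]1C(=O)N2C(C(=O)O)=C(C(C)(C)C)O[C@H]12` gives 8.1 h in an ADME assay, in phosphate buffer, at 28 degrees C, at pH 7.0; on this read-out higher numbers stand for a longer-lived compound and lower numbers for a shorter-lived compound. Compound 2 `C[C@H](O)[C@H]1C(=O)N2C(C(=O)O)=C(C(C)(C)C)O[C@H]12` gives 7.1 h in this assay, and compound 3 `COC(=O)[C@H](O)[C@H]1C(=O)N2C(C(=O)O)=C(C(C)(C)C)O[C@H]12` gives 6.7 h. The change from compound 1 to compound 2 is only a configuration as drawn, and the step is a 1.1-fold lower number from compound 1 to compound 2 (0.06 log units; within the scatter), consistent with the fact that compounds 1 and 2 differ only in the configuration as drawn. The other steps are a 1.2-fold lower number from compound 1 to compound 3 (0.08 log units; within the scatter) and a 1.1-fold lower number from compound 2 to compound 3 (0.03 log units; within the scatter). Compound 3 thus gives the lowest of the three numbers, but its steps to compound 1 and to compound 2 both sit within the scatter.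

Compound 4 `CC(C)(C)C1=C(C(=O)O)N2C(=O)[C@H]([C@@H](O)c3ccc(O)cc3)[C@H]2O1` is not yet measured. It differs from compound 3 by 4-hydroxyphenyl in place of methoxycarbonyl on a saturated chain carbon bound to an oxygen on a saturated carbon and a saturated ring carbon. The step that bears on this place is the exchange at the same carbon from compound 2 to compound 3, which gave a 1.1-fold lower number from compound 2 to compound 3 (0.03 log units; within the scatter); a larger group there left the half-life essentially unchanged. No step beyond the scatter is therefore expected, and the estimated change from compound 3 to compound 4 is a 1.0-fold lower number from compound 3 to compound 4 (0.01 log units; within the scatter). Compound 4 is expected to give about 6.5 h, within 3.5 h to 12 h.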

Compound 4, half-life: 10.3 h
Beside the measured number, compound 4's estimate is 1.6-fold (0.20 log units) below it; measured number inside the range.
By their numbers in this assay, from the lowest: compounds 3, 2, 1 and 4 (each within the scatter of the next).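

The earlier compounds shown here carried only methyl or methoxycarbonyl on this saturated chain carbon, so neither showed how this assay responds to an aromatic ring there. With 4-hydroxyphenyl in that place, the read-out shows a 1.5-fold higher number from compound 3 to compound 4 (0.19 log units; within the scatter) and a 1.5-fold higher number from compound 2 to compound 4 (0.16 log units; within the scatter), so both exchanges stay inside the usual scatter, and this carbon carries a six-membered aromatic ring and a phenolic hydroxy group without a step beyond it. No available evidence gives a cause for these two steps.

Open, from the compounds shown here alone, is whether the hydroxy group of 4-hydroxyphenyl plays any part, which a plain phenyl group at this carbon would test. Equally open, going by these compounds, is whether an amine, a carboxylic acid or a longer alkyl chain in this place would give a step beyond the scatter.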